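From Isopropyl to Tert-Butyl: Compound 3 Awaits Measurement

The source may hold more compounds than are shown below. What is called first, only, known or untested is meant among the compounds shown, and "the series" means these compounds.

Compound 1 `CC(C)N/C(=N\c1nccn1C(C)C)Nc1ccc(Cl)c(Cl)c1` and compound 2 `CC(C)n1ccnc1/N=C(\N)Nc1ccc(Cl)c(Cl)c1` share one core and differ in a single place: hydrogen in place of isopropyl on an amine nitrogen. In an in vitro ADME assay on microsomes (Macaca mulatta) for metabolic stability, read by LC-MS, tested at 1 uM (a higher number here means that the compound lasts longer, a lower number that the compound disappears faster), compound 1 gives 0.13 h. In this assay compound 2 gives > 1 h, which is a limit of the measurement rather than a number. The step of an at least 7.6-fold higher number from compound 1 to compound 2 (0.88 log units; beyond the scatter) is therefore known only as a lower bound because of the limit of > 1 h in this assay, at which 1 of the 2 values shown sits. So compound 2 stands at the upper edge of what this assay reports, with no exact number behind it.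

Compound 3 `CC(C)(C)n1ccnc1/N=C(\N)Nc1ccc(Cl)c(Cl)c1` differs from compound 2 by methyl in place of hydrogen on a saturated chain carbon bound to an aromatic nitrogen and two saturated chain carbons. Among the measured compounds shown here, the only measured step concerns a different place, the amine nitrogen, and offers no guide to a change from isopropyl to tert-butyl. For the measured compounds named here, with the starting point itself known only as a limit and no step bearing on this change, compound 3 is expected to give about 1.2 h, within a range of 0.4 h to 3 h. The estimate amounts to a step that the limit leaves unreadable from compound 2 to compound 3, which is expected to stay within the scatter.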

Compound 3, half-life: 0.75 h
For compound 3 the middle estimate is 1.6-fold (0.20 log units) above the measured one, within the range that was stated.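

The change from isopropyl to tert-butyl, a methyl in place of hydrogen on a saturated chain carbon bound to an aromatic nitrogen and two saturated chain carbons, gives this position its first reading in this assay, whereas the earlier step concerned only the amine nitrogen. Compound 2 gives > 1 h, which is a limit and not a number. The new step reads an at least 1.3-fold lower number from compound 2 to compound 3 (0.12 log units; that floor lies within the scatter), and it can show neither a real loss of stability at this position nor the absence of one, because only its floor is known and that floor lies within the usual scatter: the limit of > 1 h in this assay, at which 1 of the 3 values shown sits.

On these data alone, the true size of this step, and even whether it exceeds the scatter, stays open until compound 2 has an exact half-life. Also open, as far as these compounds go, is how a cyclopropyl group or a longer chain such as n-butyl would behave in place of tert-butyl, and whether the same change would read alike with an isopropyl group on the amine nitrogen.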